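Moving the hydroxyl on the aryl ring: a cytotoxicity estimate

The source may report more compounds than this note shows. Statements on the series, on what has been measured and on what is new or still open speak of the compounds shown alone.

Compound 1, `COc1cccc(-c2cc(C)cn3c(CSCCc4ccccc4)cnc23)c1`: 100 ug/mL
Compound 2, `Cc1cc(-c2ccc(O)cc2)cn2c(CSCCc3ccccc3)cnc12`: >= 100 ug/mL

The two measured compounds share a core that carries a methyl group and a phenethylthiomethyl chain, and differ only in the aryl ring attached to it. In an ADME assay on HEL cells (Homo sapiens) for cytotoxicity, with a stated time of 3 days (a lower number here means that less compound is tolerated, a higher number that more compound is tolerated), compound 1 gives 100 ug/mL. For compound 2 the result is a limit of the assay rather than a number: >= 100 ug/mL. Compound 2 therefore stands at the limit of >= 100 ug/mL in this assay, at which 1 of the 2 values shown sits, so its true value is not pinned down, only bounded. The two results are not distinguishable from each other on the numbers shown.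

Compound 3, `Cc1cc(-c2ccccc2O)cn2c(CSCCc3ccccc3)cnc12`, has not been measured. It differs from compound 2 by 2-hydroxyphenyl in place of 4-hydroxyphenyl on an aromatic carbon. Given that compound 2 sits at the limit of >= 100 ug/mL in this assay, at which 1 of the 2 values shown sits, and that compound 1 gives 100 ug/mL with a different aryl ring, the expected step of a number no higher from compound 2 to compound 3 (the limit leaves the size open) is none beyond the scatter. The minimum cytotoxic concentration of compound 3 in this assay is estimated at 100 ug/mL, within a range from 50 ug/mL to 100 ug/mL, with a fair chance that the assay again reports only a limit.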

Compound 3, minimum cytotoxic concentration: 100 ug/mL
For compound 3 middle estimate and measured number coincide at the digits printed; the range from low to high includes it.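

Compound 3 gives the series a number for a hydroxyphenyl ring: with the hydroxyl moved, this assay reads 100 ug/mL for compound 3. The 4-hydroxyphenyl ring of compound 2 had given only a limit. The two aryl groups have the same atoms and the same counts of donors and acceptors, so this pair isolates the place of the hydroxyl on a ring that stays on the same aromatic carbon, and the result is a number no higher from compound 2 to compound 3 (the limit leaves the size open). The size of that step cannot be read, so the pair does not show whether moving the hydroxyl changes tolerance at all, and the value for compound 2 remains a limit: the limit of >= 100 ug/mL in this assay, at which 1 of the 3 values shown sits.

As far as these compounds go, whether the true value of compound 2 lies well beyond that of compound 3 stays open, and with it whether 2-hydroxyphenyl is any different from 4-hydroxyphenyl in this cell test. Also open, from the compounds shown here alone, is how an amine or a carboxylic acid in place of the hydroxyl on this aryl ring would read, and what a longer chain in place of the phenethylthiomethyl chain would do.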